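Removing the 4-cyanophenyl group of compound 1 entirely

A few compounds are considered here, and "the series" means these few. Any claim that something is new, unique, unknown or untested is made for them only; others in the source may bear on it.

Compound 1 `Cc1n[nH]c(C(=O)O)c1Cc1cccc(-c2ccc(C#N)cc2)c1` gives 13% in an assay on isolated protein for inhibition of 2-Hydroxyacid oxidase 2 (Homo sapiens), tested at 1 uM (a higher number here means a stronger effect of the compound at the concentration tested, a lower number a weaker effect), the highest of the three numbers, though compound 2 `Cc1n[nH]c(C(=O)O)c1Cc1cccc(-c2ccc(C(F)(F)F)cc2)c1` with 8% and compound 3 `Cc1n[nH]c(C(=O)O)c1Cc1cccc(-c2ccc(C(=O)O)cc2)c1` with 3% both lie within the scatter of it, as the steps of a number 5 percentage points lower from compound 1 to compound 2 (within the scatter) and a number 10 percentage points lower from compound 1 to compound 3 (within the scatter) show. Compound 4 `Cc1n[nH]c(C(=O)O)c1Cc1cccc(C#N)c1` differs from compound 1 by cyano in place of 4-cyanophenyl on an aromatic carbon. Within the data shown here, no measured step bears on this change: each measured step only exchanges cyano, trifluoromethyl or carboxy for one another, and all three fall within the scatter. Nothing in the series therefore gives a direction; a step beyond the scatter either way cannot be excluded, but every measured number is low. Compound 4 is expected to give 8%, between -2% and 22%, an expected step of a number 5 percentage points lower from compound 1 to compound 4 (within the scatter).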

Compound 4, a percentage reported as inhibition, at one concentration (the size of the read-out at that concentration, not a potency): 6%
Estimate against measurement, compound 4: 2 percentage points above; the measured number falls inside the stated range.
By their numbers in this assay, from the lowest: compounds 3, 4, 2 and 1 (each within the scatter of the next).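

In this assay, cyano in place of 4-cyanophenyl on the aromatic carbon gives a number 7 percentage points lower from compound 1 to compound 4 (within the scatter). Unlike the earlier exchanges, this change removes the whole six-membered aromatic ring of carbon only, yet the read-out does not separate the two compounds, so that ring is not shown to matter at this concentration. No evidence on hand accounts for this result.

Going by these compounds, whether any group at this position can raise the read-out beyond the scatter remains open, for instance an amine or a methoxy group in place of cyano. Also open, on these data alone, is how the shared core behaves with hydrogen alone there.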